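A few compounds are considered here, and "the series" means these few. Any claim that something is new, unique, unknown or untested is made for them only; others in the source may bear on it.

Compound 1 `CCN(CC)C(=O)CN(c1cc(Cl)ccc1OC)S(=O)(=O)c1ccccc1`, in a functional assay on SH-SY5Y cells (Homo sapiens), read by MTT assay, with a stated time of 24 h (a lower number here means that less compound is needed, a higher number that more compound is needed for the effect), gives > 20000 nM, which is a limit of the assay.
Compound 2 `COc1ccc(Cl)cc1N(CC(=O)Nc1ccccc1)S(=O)(=O)c1ccccc1` gives > 20000 nM, again only a limit.
Compound 3 `CCn1ccc2cc(NC(=O)CN(c3cc(Cl)ccc3OC)S(=O)(=O)c3ccccc3)ccc21` gives 2220 nM.

Compound 2 thus stands at the limit of > 20000 nM in this assay, at which 2 of the 3 values shown sit; no number is known for it, and compound 1 sits at the same limit. Compound 4 `CCCNC(=O)CN(c1cc(Cl)ccc1OC)S(=O)(=O)c1ccccc1` differs from compound 2 by propyl in place of phenyl on an amide-type nitrogen. Of the measured steps, a step that the two limits leave unreadable from compound 1 to compound 2, so nothing about its size can be read. The other step, an at least 9.0-fold lower number from compound 2 to compound 3 (0.95 log units; beyond the scatter), runs toward the indolyl group and away from the direction taken by compound 4. Compound 4 carries propyl on the amide nitrogen, and compound 1, which carries diethylamino on the carbonyl carbon, reaches only the limit in this assay. The expectation for compound 4 is therefore no step beyond the scatter, a step that the limit leaves unreadable from compound 2 to compound 4, with a limit the most likely outcome. The estimate for compound 4 is 25000 nM, between 8000 nM and 60000 nM.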

Compound 4, half-maximal effective concentration: > 20000 nM
Compound 4 was reported as a limit; the forecaster's own chance of this, stated with the estimate: 75%; the middle value is on the limit's open side.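

In this assay, replacing the 1-ethyl-1H-indol-5-yl group with propyl on the amide-type nitrogen gives an at least 9.0-fold higher number from compound 3 to compound 4 (0.95 log units; beyond the scatter). Compound 4 stands only at a limit of the assay, so propyl, like phenyl, yields no number at this position, and compound 3 remains the only compound shown with a measured value: the limit of > 20000 nM in this assay, at which 3 of the 4 values shown sit. The steps to compound 4 from compound 1 and from compound 2 cannot be read, as both ends of each are limits.

From the compounds shown here alone, it remains open whether a 1H-indol-5-yl group without the ethyl, a benzyl group or a longer chain on this nitrogen would give a number. Also open, going by these compounds, is how far compound 1, compound 2 and compound 4 lie past the limit, and whether they differ at all.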